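The source may report more compounds than this note shows. Statements on the series, on what has been measured and on what is new or still open speak of the compounds shown alone.

Measured compounds:
compound 1, `COc1cc([C@@H](O)[C@@H](CO)Oc2c(OC)cc([C@@H](O)[C@H](O)CO)cc2OC)ccc1O`, 138000 nM
compound 2, `COc1cc([C@@H](O)[C@H](CO)Oc2c(OC)cc([C@@H](O)[C@H](O)CO)cc2OC)ccc1O`, 114000 nM
compound 3, `CCO[C@H](c1ccc(O[C@@H](CO)[C@@H](OC)c2ccc(O)c(OC)c2)c(OC)c1)[C@H](CO)c1ccc(O)c(OC)c1`, 81600 nM

All three numbers come from a functional assay, with a stated time of 30 min; on this read-out lower numbers stand for stronger inhibition and higher numbers for weaker inhibition. Compound 3 gives the lowest of the three, but its gaps to compound 2 and to compound 1 both lie within the scatter, so no order among the three can be read from them. Within the data shown here, the only step between compounds that differ in a single place is a 1.2-fold lower number from compound 1 to compound 2 (0.08 log units; within the scatter); it rests on the fact that compounds 1 and 2 differ only in the configuration as drawn and is itself within the scatter.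

Compound 4, `CCO[C@H](c1ccc(O[C@@H](CO)[C@@H](O)c2ccc(O)c(OC)c2)c(OC)c1)[C@H](CO)c1ccc(O)c(OC)c1`, is not yet measured in this assay. It differs from compound 3 as follows: hydrogen in place of methyl on an oxygen on a saturated carbon. Among the measured compounds shown here, no measured step involves a methyl leaving an oxygen on a saturated carbon, and the single step at hand concerns configuration alone, so it gives no guidance for this change. With nothing pointing either way, the expected step is a 1.0-fold lower number from compound 3 to compound 4 (0.01 log units; within the scatter), within the scatter. Compound 4 is therefore estimated at 80000 nM, with a range from 35000 nM to 180000 nM.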

Compound 4, half-maximal inhibitory concentration: 56800 nM
The estimate for compound 4 lay 1.4-fold (0.15 log units) above the measured number, and the stated range covers the measured number.
By their numbers in this assay, from the lowest: compounds 4, 3, 2 and 1 (each within the scatter of the next, the first and the last beyond it).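

In this assay, among these compounds, hydrogen in place of methyl on an oxygen on a saturated carbon gives a 1.4-fold lower number from compound 3 to compound 4 (0.16 log units; within the scatter), the first reading of any change at this oxygen. With either methoxy or hydroxy at this place, the two compounds cannot be told apart on this read-out, so the methyl is not shown to matter here in either direction. Nothing measured on these compounds speaks to a cause for this step.

Still open, on these data alone, is whether a longer chain on this oxygen, or an amine or a carboxylic acid at this place, would give a step beyond the scatter. Also open, as far as these compounds go, is whether the change from methoxy to hydroxy would read the same with the opposite configuration at this saturated carbon.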